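This account rests on a few compounds, and the source may have more. Where it says the series, first, only, none or still open, it means among the compounds named here.

In a functional assay on A-375 cells (Homo sapiens) for antiproliferative activity (on this read-out higher numbers stand for weaker inhibition and lower numbers for stronger inhibition), three compounds sharing one core have been measured, and they differ only in the aromatic ring carried on the aromatic carbon. Compound 1 `O=C(Nc1ccc(-c2cscn2)cc1)C1CCCN(Cc2ccc(F)c(F)c2)C1` gives 880 nM, compound 2 `O=C(Nc1ccc(-c2ccccc2)cc1)C1CCCN(Cc2ccc(F)c(F)c2)C1` gives 2580 nM and compound 3 `O=C(Nc1ccc(-c2ccncc2)cc1)C1CCCN(Cc2ccc(F)c(F)c2)C1` gives 600 nM. Compound 3 holds the lowest number, but it cannot be separated from its nearest neighbour: a 1.5-fold lower number from compound 1 to compound 3 (0.17 log units; within the scatter). The gaps to compound 2 are modest but real, with a 2.9-fold higher number from compound 1 to compound 2 (0.47 log units; beyond the scatter) and a 4.3-fold lower number from compound 2 to compound 3 (0.63 log units; beyond the scatter).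

Compound 4 `O=C(Nc1ccc(-c2cccnc2)cc1)C1CCCN(Cc2ccc(F)c(F)c2)C1`, not yet measured, differs from compound 3 by one change: pyridin-3-yl in place of pyridin-4-yl on an aromatic carbon. This places pyridin-3-yl in place of pyridin-4-yl on an aromatic carbon. Among the measured compounds shown here, no measured step moves the nitrogen within a pyridine ring, so the evidence is indirect. Still, exchanging one hetero-aromatic ring for another gave only a 1.5-fold lower number from compound 1 to compound 3 (0.17 log units; within the scatter), while the larger step, a 4.3-fold lower number from compound 2 to compound 3 (0.63 log units; beyond the scatter), involved loss of the hetero atom. A small change is therefore expected, probably no larger than the scatter: a 1.3-fold higher number from compound 3 to compound 4 (0.12 log units; within the scatter). Compound 4 is estimated at 800 nM, with an expected range from 350 nM to 1800 nM.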

Compound 4, half-maximal inhibitory concentration: 610 nM
Estimate against measurement, compound 4: 1.3-fold (0.12 log units) above; the range from low to high includes it.
By their numbers in this assay, from the lowest: compounds 3, 4 and 1 (each within the scatter of the next); then compound 2.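

In this assay, moving the ring nitrogen from pyridin-4-yl to pyridin-3-yl, on an aromatic carbon para to a large group, makes no difference beyond the scatter (a 1.0-fold higher number from compound 3 to compound 4 (0.01 log units; within the scatter)). The advantage of these pyridine rings over phenyl therefore does not depend on which of the two positions holds the nitrogen (a 4.2-fold lower number from compound 2 to compound 4 (0.63 log units; beyond the scatter)). The pyridin-3-yl ring also stands level with 1,3-thiazol-4-yl (a 1.4-fold lower number from compound 1 to compound 4 (0.16 log units; within the scatter)), so the three hetero-aromatic rings shown form one group, with only phenyl apart from them.

Nothing available explains why these rings behave alike. As far as these compounds go, whether a pyridin-2-yl ring, or a pyridine carrying an amine or a carboxylic acid, would stay at this level remains open.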